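Series notes: chloro for methyl on the aryl ring

The source may report more compounds than this note shows. Statements on the series, on what has been measured and on what is new or still open speak of the compounds shown alone.

Compound 1 `Cc1ccc(-c2c[nH]nc2S(=O)(=O)CC2=NCCS2)cc1` carries a methyl on its pendant aromatic ring. In a functional assay, tested at 75 ug/mL (on this read-out higher numbers stand for a stronger effect at the one concentration tested and lower numbers for a weaker effect), compound 1 is reported as "not active" (no number reported), so no single number marks where it stands; it is simply recorded as inactive at the one concentration tested. Compound 2 `COc1ccc(-c2noc(-c3ccc(C)cc3)c2S(=O)(=O)CC2=NCCO2)cc1` differs from compound 1 in several places at once; in this assay compound 2 gives 72%, and its two values against compound 1 are all that can be said of that pair.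

Compound 3 `O=S(=O)(CC1=NCCS1)c1n[nH]cc1-c1ccc(Cl)cc1` is the untested analogue of compound 1; the change is chloro in place of methyl on an aromatic carbon. With no measured step of this kind in the series, the expectation for this assay is a step of no size beyond the scatter, in no particular direction, since compound 1 gave no number and the change exchanges one heavy atom for another.

Compound 3 is therefore estimated at 10%, with a range from 0% to 35%, and a real chance that only an inactive call is reported, as for compound 1.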

Compound 3, a percentage reported as activity, at one concentration (the size of the read-out at that concentration, not a potency): "not active" (no number reported)
The entry for compound 3 holds no number, so the estimate cannot be set against anything.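

In this assay compound 3 gives "not active" (no number reported) and compound 1 gives "not active" (no number reported) so no step can be read from this pair. No further data bear on this result. The compounds shown leave open what 4-methylphenyl to 4-chlorophenyl does where a number is reported.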